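The source may report more compounds than this note shows. Statements on the series, on what has been measured and on what is new or still open speak of the compounds shown alone.

Compound 2 `COc1ccc(CN2C(=O)C(=O)c3cc(/C=C/C(=O)N4CCCC4)ccc32)cc1` and compound 1 `CCOC(=O)/C=C/c1ccc2c(c1)C(=O)C(=O)N2Cc1ccc(OC)cc1` share one core and differ in a single place: ethoxy in place of pyrrolidin-1-yl on a carbonyl carbon. In a functional assay on HT-29 cells (Homo sapiens) for cytotoxicity, read by MTT assay, with a stated time of 48 h (a lower number here means a stronger inhibitor, a higher number a weaker inhibitor), compound 2 gives 5230 nM, whereas compound 1 gives 60 nM in this assay, so that an 87-fold lower number from compound 2 to compound 1 (1.94 log units; beyond the scatter). Compound 3 `O=C1C(=O)N(Cc2ccc(Br)cc2)c2ccc(/C=C/C(=O)N3CCCC3)cc21` keeps the (pyrrolidin-1-yl)carbonyl group of compound 2 but sits on the other core; the two cores differ in that (bromo in place of methoxy on an aromatic carbon). In this assay compound 3 gives 4420 nM, and a 1.2-fold lower number from compound 2 to compound 3 (0.07 log units; within the scatter), so the two cores give closely matching numbers with this amide in place.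

Compound 4 `CCOC(=O)/C=C/c1ccc2c(c1)C(=O)C(=O)N2Cc1ccc(Br)cc1` has not yet been tested in this assay. It stands to compound 3 exactly as compound 1 stands to compound 2: ethoxy in place of pyrrolidin-1-yl on a carbonyl carbon, at a place described in identical terms in both pairs, so this is the same change made once more, now on the bromobenzyl core.

Compound 4 is expected to show a drop comparable to the earlier one, an 80-fold lower number from compound 3 to compound 4 (1.91 log units; beyond the scatter) in this assay, because an 87-fold lower number from compound 2 to compound 1 (1.94 log units; beyond the scatter) on the matching core. On that basis compound 4 is estimated at 55 nM, with a likely range from 20 nM to 160 nM.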

Compound 4, half-maximal inhibitory concentration: 50 nM
For compound 4 the middle estimate is 1.1-fold (0.04 log units) above the measured one, within the range that was stated.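

With ethoxy in place of pyrrolidin-1-yl on the carbonyl carbon, this assay gives an 88-fold lower number from compound 3 to compound 4 (1.95 log units; beyond the scatter), and the change carries from the core of compound 2 to the core of compound 3 at essentially the same size: the same change on two cores in this assay, an 87-fold lower number (1.94 log units; beyond the scatter) from compound 2 to compound 1 and an 88-fold lower number (1.95 log units; beyond the scatter) from compound 3 to compound 4, 1.0-fold (0.01 log units) apart, within the scatter of two such steps. Bromo in place of methoxy remains as small a step with the ethoxycarbonyl group as with the (pyrrolidin-1-yl)carbonyl group, at a 1.2-fold lower number from compound 1 to compound 4 (0.08 log units; within the scatter), so the two cores stay matched: the same change on two cores in this assay, a 1.2-fold lower number (0.07 log units; within the scatter) from compound 2 to compound 3 and a 1.2-fold lower number (0.08 log units; within the scatter) from compound 1 to compound 4, 1.0-fold (0.01 log units) apart, within the scatter of two such steps. This shows that the two changes combine without interference across these four compounds, but it rests on a single pair of cores that differ only in bromo and methoxy, and it does not show that the step would hold on a more distant core or explain its size.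

As far as these compounds go, it remains open whether a carboxylic acid or a piperidin-1-yl amide on the same carbonyl carbon would track with ethoxy or with pyrrolidin-1-yl. From the compounds shown here alone, it is also open whether chloro or a plain hydrogen in place of bromo would keep the cores matched.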